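Acetylating the Amino Group on Two Related Cores

A few compounds are considered here, and "the series" means these few. Any claim that something is new, unique, unknown or untested is made for them only; others in the source may bear on it.

Measured in a functional assay on L1210 cells (Mus musculus) for antiproliferative activity; a lower number here means a stronger inhibitor, a higher number a weaker inhibitor:
compound 1, `Nc1nc(CN=C=S)cs1`: 26000 nM
compound 2, `Nc1nc(CN=C=S)c[se]1`: 21000 nM
compound 3, `CC(=O)Nc1nc(CN=C=S)cs1`: 5200 nM

Compound 1 and compound 2 have different cores; that difference is not broken down here, and their two numbers lie within the scatter of each other. Compound 3 carries acetyl in place of hydrogen on a nitrogen on an aromatic ring, and that change gave a 5.0-fold lower number from compound 1 to compound 3 (0.70 log units; beyond the scatter).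

Compound 4, `CC(=O)Nc1nc(CN=C=S)c[se]1`, has not yet been measured. It carries acetyl in place of hydrogen on a nitrogen on an aromatic ring, the same change made at the same kind of place, now on the core of compound 2. For the measured compounds named here, the step from compound 2 to compound 4 is expected to be of similar size, a 5.0-fold lower number from compound 2 to compound 4 (0.70 log units; beyond the scatter), because the single measured example of this change gave a 5.0-fold lower number from compound 1 to compound 3 (0.70 log units; beyond the scatter). Going by the values given here, with only one such example, the range is kept wide. Compound 4 is therefore estimated at 4200 nM, most likely between 1800 nM and 10000 nM.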

Compound 4, half-maximal inhibitory concentration: 30000 nM
Compound 4: the middle estimate sits 7.1-fold (0.85 log units) below what was measured; the whole stated range lies below it.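

Putting the acetyl group on compound 2 did not repeat the gain seen on the other core in this assay; the result was a 1.4-fold higher number from compound 2 to compound 4 (0.15 log units; within the scatter). The same change therefore did not carry over from one core to the other, and the two steps differ clearly: the same change on two cores in this assay, a 5.0-fold lower number (0.70 log units; beyond the scatter) from compound 1 to compound 3 and a 1.4-fold higher number (0.15 log units; within the scatter) from compound 2 to compound 4, 7.1-fold (0.85 log units) apart, beyond the scatter of two such steps. For the compounds shown here, this shows that in these compounds the effect of going from amino to acetamido depends on the core, but with only one pair per core it does not show why, or what would happen on a further core.

Going by these compounds, it remains open how other groups on the same nitrogen, such as a methyl group or a longer butanoyl chain, would behave on each core.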